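Turning the Stereocentre: Compound 2 to Its Mirror Image

The compounds below may be only part of what the source reports. "The series", "measured", "known", "first", "only" and "open" are said of these compounds alone.

Measured compounds:
Compound 1, `NC(=O)c1cnc2ccc(-c3cccnc3)cc2c1NC1CCCCC1`: 70 uL/min
Compound 2, `C[C@@H](Nc1c(C(N)=O)cnc2ccc(-c3cccnc3)cc12)C1CCOCC1`: 46 uL/min

In an ADME assay on cells (Hepatocyte, Rattus norvegicus) for metabolic stability, with a stated time of 90 min (on this read-out lower numbers stand for slow clearance and higher numbers for fast clearance), compound 1 gives 70 uL/min. Compound 2 gives 46 uL/min in this assay. Among the measured compounds shown here, the one measured step, a 1.5-fold lower number from compound 1 to compound 2 (0.18 log units; within the scatter), puts compound 2 at the lower of the two numbers, though by a margin that sits within the scatter, so the two compounds cannot be ordered.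

Compound 3, `C[C@H](Nc1c(C(N)=O)cnc2ccc(-c3cccnc3)cc12)C1CCOCC1`, is not yet measured. It differs from compound 2 as follows: the two compounds have the same atoms and bonds and differ only in configuration as drawn: 1 of 1 stereo elements differ; a stereocentre at a saturated chain carbon is drawn R in compound 2 and S in compound 3.

For the measured compounds named here, no measured step here concerns a change of configuration alone, so there is nothing to draw on except the values of compound 1 and compound 2. The step expected from this change is therefore no change at the digits printed from compound 2 to compound 3 (within the scatter), with no movement beyond the scatter. Compound 3 is estimated at 46 uL/min in this assay, within a range from 23 uL/min to 92 uL/min.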

Compound 3, intrinsic clearance in a liver preparation (reported as CLH), per the amount of preparation that the assay uses: 38 uL/min
Estimate against measurement, compound 3: 1.2-fold (0.08 log units) above, within the range that was stated.
By their numbers in this assay, from the lowest: compounds 3, 2 and 1 (each within the scatter of the next).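

In this assay, inverting the stereocentre on the 1-(oxan-4-yl)ethyl group gives a 1.2-fold lower number from compound 2 to compound 3 (0.08 log units; within the scatter), so the two mirror-image forms cannot be told apart at this position on this read-out. This comparison tests configuration alone, with nothing else in the structure to account for the result: the fact that compounds 2 and 3 differ only in the configuration as drawn. Placing the S form of this group where cyclohexyl stood gives a 1.8-fold lower number from compound 1 to compound 3 (0.27 log units; within the scatter), so the S form, like the R form, cannot be separated from cyclohexyl.

The compounds shown leave open whether an amine or a carboxylic acid on this group, or a longer chain in its place, would move the clearance beyond the scatter. They also leave open whether the two mirror-image forms would differ on any other read-out.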